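This account rests on a few compounds, and the source may have more. Where it says the series, first, only, none or still open, it means among the compounds named here.

In a functional assay on WM 266-4 cells (Homo sapiens) for antiproliferative activity, read by MTT assay, with a stated time of 24 h (on this read-out lower numbers stand for stronger inhibition of growth and higher numbers for weaker inhibition of growth), the measured compounds gave the following numbers:

compound 1 `COc1ccc(C2=NN(C(=O)c3ccc(Cl)nc3)C(c3ccc(Cl)cc3)C2)cc1`: 1450 nM
compound 2 `COc1ccc(C2=NN(C(=O)c3ccc(C)nc3Cl)C(c3ccc(Cl)cc3)C2)cc1`: 1440 nM
compound 3 `O=C(c1ccc(Cl)nc1)N1N=C(c2ccc(Cl)cc2)CC1c1ccc(OCc2ccccc2)cc1`: 13200 nM

Compound 1 and compound 2 share a core and differ in a single place: 2-chloro-6-methylpyridin-3-yl in place of 6-chloropyridin-3-yl on a carbonyl carbon. This step, a 1.0-fold lower number from compound 1 to compound 2 (0.00 log units; within the scatter), left the read-out essentially unchanged. Compound 3 carries a different core; how it differs from compound 1 is not broken down here. Compound 3 gives the highest number of the three, lying well beyond the scatter relative to both compound 1 and compound 2, so it is the weakest inhibitor of growth among the measured set.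

Compound 4 `Cc1ccc(C(=O)N2N=C(c3ccc(Cl)cc3)CC2c2ccc(OCc3ccccc3)cc2)c(Cl)n1` is not yet measured. It is related to compound 3 by the same change that links compound 1 to compound 2: 2-chloro-6-methylpyridin-3-yl in place of 6-chloropyridin-3-yl on a carbonyl carbon. The place is described in identical words for both pairs, so the change is the same, made on a different core.

Because the earlier step of a 1.0-fold lower number from compound 1 to compound 2 (0.00 log units; within the scatter) was within the scatter, the step from compound 3 to compound 4 is expected to be of similar size, a 1.0-fold lower number from compound 3 to compound 4 (0.01 log units; within the scatter). Among the measured compounds shown here, compound 4 is therefore estimated at 13000 nM, with a plausible range from 6000 nM to 28000 nM, given that only one prior instance of the change is available and it sits on a different core.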

Compound 4, concentration for 50% growth inhibition: 11400 nM
Beside the measured number, compound 4's estimate is 1.1-fold (0.06 log units) above it; the measured number falls inside the stated range.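

In this assay, among the compounds shown here, the exchange of 6-chloropyridin-3-yl for 2-chloro-6-methylpyridin-3-yl on the carbonyl carbon gave a 1.2-fold lower number from compound 3 to compound 4 (0.06 log units; within the scatter) and so, on the core of compound 3, produced no step that can be told from the scatter. The change therefore behaved alike on both cores shown, and the two instances cannot be told apart: the same change on two cores in this assay, a 1.0-fold lower number (0.00 log units; within the scatter) from compound 1 to compound 2 and a 1.2-fold lower number (0.06 log units; within the scatter) from compound 3 to compound 4, 1.1-fold (0.06 log units) apart, within the scatter of two such steps. For the compounds shown here, this shows only that the change can be carried between these two cores without a measurable step in this growth read-out; it does not show that the same would hold on a third core, and with just two pairs, neither of which moves the read-out, it gives no test of whether a change with a real effect would carry over in the same way.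

Every pyridine shown bears a chlorine, and the only further group among them is a methyl, so it remains open how the read-out would respond to an amine or a carboxylic acid on that ring, or to a longer chain such as propyl in place of the methyl. From the compounds shown here alone, whether such groups would behave alike on the two cores also remains open.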